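A few compounds are considered here, and "the series" means these few. Any claim that something is new, unique, unknown or untested is made for them only; others in the source may bear on it.

Measured compounds:
Compound 1 `Cc1ncnc2c1c(-c1cccs1)cn2[C@@H]1O[C@H](CO)[C@@H](O)[C@H]1O` gives in a functional assay on HepG2 cells (Homo sapiens) for antiproliferative activity, read by XTT assay, with a stated time of 72 h (on this read-out lower numbers stand for stronger inhibition and higher numbers for weaker inhibition), only a limit of the assay, > 15000 nM.
Compound 2 `CNc1ncnc2c1c(-c1cccs1)cn2[C@@H]1O[C@H](CO)[C@@H](O)[C@H]1O` gives in this assay only a limit, > 20000 nM.
Compound 3 `CNc1ncnc2c1c(-c1ccsc1)cn2[C@@H]1O[C@H](CO)[C@@H](O)[C@H]1O` gives in this assay only a limit, > 20000 nM.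

Compound 4 `Cc1ncnc2c1c(-c1ccsc1)cn2[C@@H]1O[C@H](CO)[C@@H](O)[C@H]1O` has not yet been measured. From compound 2 to compound 1 the change is methyl in place of methylamino on an aromatic carbon, and it gave a step that the two limits leave unreadable from compound 2 to compound 1, a step that cannot be read because the limit of > 20000 nM in this assay, at which 2 of the 3 values shown sit, and the limit of > 15000 nM in this assay, at which 1 of the 3 values shown sits, leave only limits on either side. The cores of compound 2 and compound 3 differ by thiophen-3-yl in place of thiophen-2-yl on an aromatic carbon, which gave a step that the two limits leave unreadable from compound 2 to compound 3. The same change, (methyl in place of methylamino on an aromatic carbon), leads from compound 3 to compound 4, at a place described in the same words. For compound 4 the step is expected to be a number no higher from compound 3 to compound 4 (the limit leaves the size open). This expectation rests on compound 1, whose value in this assay is a limit, > 15000 nM. Compound 4 is therefore estimated at 20000 nM, between 8000 nM and 50000 nM, and will most likely itself be reported only as a limit.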

Compound 4, half-maximal inhibitory concentration: 4720 nM
Compound 4: middle estimate off by 4.2-fold (0.63 log units), on the high side; the measured number lies below the stated range.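

In this assay, going by these compounds alone, methyl in place of methylamino gave an at least 4.2-fold lower number from compound 3 to compound 4 (0.62 log units; beyond the scatter), and thiophen-3-yl in place of thiophen-2-yl gave an at least 3.1-fold lower number from compound 1 to compound 4 (0.50 log units; beyond the scatter), so compound 4 is the only one of the four compounds with a measured number. The steps among compound 1, compound 2 and compound 3 cannot be read, as each has a limit on both sides. On these data alone, the methyl change therefore lowers the number on the core of compound 3, but whether it carries over to the core of compound 2, and by how much, remains unknown.

The compounds shown leave open whether ethyl or a plain amino group at the same place would give a number like that of compound 4. As far as these compounds go, the true values behind the limits also stay open.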